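A few compounds are considered here, and "the series" means these few. Any claim that something is new, unique, unknown or untested is made for them only; others in the source may bear on it.

Working notes on the thiocarbamate series. The shared core is carried by compound 1 `O=[N+]([O-])c1ccc(NC(=S)OCCc2ccccc2)cc1`, compound 2 `Cc1ccc(NC(=S)OCCc2ccncc2)cc1` and compound 3 `S=C(Nc1ccc(Cl)cc1)OCCc1ccncc1`. In an ADME assay on MT4 cells (Homo sapiens) for cytotoxicity, read by MTT assay (a lower number here means that less compound is tolerated, a higher number that more compound is tolerated), compound 1 reaches only a limit of the assay, > 100000 nM, not a number. Compound 2 likewise sits at a limit in this assay, > 100000 nM. Going by the values given here, compound 3 is the one member with a number in this assay, 70000 nM. The other two values shown are limits, as the limit of > 100000 nM in this assay, at which 2 of the 3 values shown sit, records. Among the compounds with values here, the single measured step, an at least 1.4-fold lower number from compound 2 to compound 3 (0.15 log units; that floor lies within the scatter), is small and its floor lies within the scatter, so no change beyond the scatter is established between those two compounds.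

Compound 4 `O=[N+]([O-])c1ccc(NC(=S)OCCc2ccncc2)cc1` is not yet measured. It differs from compound 3 by nitro in place of chloro on an aromatic carbon. The measured step between compound 2 and compound 3 is the only one at the same position on that ring and it bears on this change; it showed nothing beyond the scatter. Compound 1, the other nitro compound shown, sits at a limit and compound 3 sits at a number within the scatter of that limit. For compound 4 a step of a 1.4-fold higher number from compound 3 to compound 4 (0.15 log units; within the scatter) in this assay is expected, within the scatter. The estimate for compound 4 in this assay is 100000 nM, with a range from 50000 nM to 250000 nM, and a fair chance that the assay again reports only a limit.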

Compound 4, half-maximal cytotoxic concentration: > 100000 nM
Compound 4 gave a limit, no number; the forecaster's own chance of this, stated with the estimate: 55%; the middle value sits exactly at the limit.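

At this position, on an aromatic carbon para to a large group, nitro in place of chloro gives in this assay an at least 1.4-fold higher number from compound 3 to compound 4 (0.15 log units; that floor lies within the scatter), so the change establishes no shift beyond the scatter. Nitro now stands on the shared core with both phenyl and pyridin-4-yl, in compound 1 and compound 4, and each of these gives a limit of the assay, not a number, so the earlier nitro result is not confined to the phenyl compound. The steps to compound 4 from compound 2 and from compound 1 cannot be read, and compound 3 remains the only member with a number: the limit of > 100000 nM in this assay, at which 3 of the 4 values shown sit.

Going by these compounds alone, it stays open what an amine or a carboxylic acid in place of nitro would give at this position, and what a longer chain would give in place of the one carrying the pyridin-4-yl group. Also open, going by these compounds, is how the true values of compound 1, compound 2 and compound 4 stand relative to one another, as the assay gives only a limit for each.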